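The source may hold more compounds than are shown below. What is called first, only, known or untested is meant among the compounds shown, and "the series" means these compounds.

In a physicochemical assay for lipophilicity, read by HPLC, measured as octanol-water partition, at pH 7.2 (a lower number here means a more polar compound, a higher number a more lipophilic compound), compound 1 `CC(=O)c1ccc(NC(=O)Nc2ccc(F)c(C(F)(F)F)c2)cc1` gives 3.6 and stands highest of the two numbers in hand, while compound 2 `N#Cc1ccc(NC(=O)Nc2ccnc(C(F)(F)F)c2)cc1` gives 3 and lies lower by a gap beyond the scatter. Compound 3 `O=C(Nc1ccc(C(=O)O)cc1)Nc1ccc(F)c(C(F)(F)F)c1` is still unmeasured. It differs from compound 1 in one place (hydroxy in place of methyl on a carbonyl carbon): hydroxy in place of methyl on a carbonyl carbon, acetyl to carboxy. Among the compounds with values here, no measured pair shows this change, so the expectation rests on the structural change alone. A large downward step is expected in this assay (a number 1.80 log units lower from compound 1 to compound 3 (beyond the scatter)). For compound 3 the estimate is 1.8 (expected range 1 to 2.6).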

Compound 3, distribution coefficient: 1.5
Estimate against measurement, compound 3: 0.30 log units above; the measured number falls inside the stated range.
By their numbers in this assay, from the lowest: compound 3; then compound 2; then compound 1.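

In this assay, hydroxy in place of methyl on a carbonyl carbon, acetyl to carboxy, gives a number 2.10 log units lower from compound 1 to compound 3 (beyond the scatter), a large step. This is the first change in one place among these compounds, and it shows that this position on the core of compound 1 can move the number substantially. Nothing available here explains the size of the step. On these data alone, whether a methyl ester or a primary amide on this carbonyl carbon would give a step of similar size remains open. So does whether the same change would give a similar step on the core of compound 2.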